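Methoxy on the Fused Ring of Chloroquinoline Styrenes

The source may report more compounds than this note shows. Statements on the series, on what has been measured and on what is new or still open speak of the compounds shown alone.

Compound 1 `FC(F)(F)c1ccc(/C=C\c2cc3ccccc3nc2Cl)cc1` and compound 3 `FC(F)(F)c1cccc(/C=C\c2cc3ccccc3nc2Cl)c1` share the same atoms joined differently; the difference between their two cores is not broken down here. In an ADME assay on 184B5 cells (Homo sapiens) for antiproliferative activity, read by sulforhodamine B assay, with a stated time of 72 h (on this read-out higher numbers stand for weaker inhibition and lower numbers for stronger inhibition), compound 1 gives 7940 nM, and compound 3 gives 6150 nM, and these two numbers lie within the scatter of each other, so no order between them is claimed. Compound 2 `COc1ccc2nc(Cl)c(/C=C\c3ccc(C(F)(F)F)cc3)cc2c1` carries a methoxy in place of hydrogen on an aromatic carbon of the core of compound 1, the change being (methoxy in place of hydrogen on an aromatic carbon). In this assay compound 2 gives 40000 nM, which is a 5.0-fold higher number from compound 1 to compound 2 (0.70 log units; beyond the scatter).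

Compound 4 `COc1ccc2nc(Cl)c(/C=C\c3cccc(C(F)(F)F)c3)cc2c1` stands to compound 3 as compound 2 stands to compound 1: the change is methoxy in place of hydrogen on an aromatic carbon, and the two place descriptions agree word for word, so it is the same change made on the other core. Going by the values given here, only this one pair of measured compounds shows the change, and nothing further is known about how the two cores respond to it. Resting on the step that compound 2 showed against compound 1, the account expects compound 4 to lie at 28000 nM in this assay, a step of a 4.6-fold higher number from compound 3 to compound 4 (0.66 log units; beyond the scatter), with the range 10000 nM to 60000 nM marking how far a single measured pair can be trusted before the result for compound 4 is known.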

Compound 4, half-maximal inhibitory concentration: 5580 nM
The estimate for compound 4 lay 5.0-fold (0.70 log units) above the measured number; measured number below the stated range.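

In this assay, going by these compounds alone, methoxy in place of hydrogen on an aromatic carbon of the second core gives a 1.1-fold lower number from compound 3 to compound 4 (0.04 log units; within the scatter), so on this core the change leaves no step that can be told from the scatter. The step measured on the first core therefore did not carry over to the second, even though the two cores share the same atoms joined differently and the change was described in the same words on both: the same change on two cores in this assay, a 5.0-fold higher number (0.70 log units; beyond the scatter) from compound 1 to compound 2 and a 1.1-fold lower number (0.04 log units; within the scatter) from compound 3 to compound 4, 5.6-fold (0.74 log units) apart, beyond the scatter of two such steps This shows that, for these four compounds, the size of the step depends on the core that receives the methoxy, but it does not show what in the two cores sets them apart, and with a single pair on each core it gives no rule for what the same change would do on any further core.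

The compounds shown leave open whether a different group in the same place, such as an ethoxy, a longer chain, a hydroxyl or an amine, would also give steps that differ between the two cores. They also leave open whether the difference between the two steps would hold in a read-out on other cells.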